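A Methoxyphenyl Swap in a Cytotoxicity Series

This account rests on a few compounds, and the source may have more. Where it says the series, first, only, none or still open, it means among the compounds named here.

In a toxicity assay on MT4 cells (Homo sapiens) for cytotoxicity, read by MTT assay (a higher number here means that more compound is tolerated, a lower number that less compound is tolerated), compound 1 `Cc1cc(-c2ccccc2F)cc(C)c1Oc1cc(N)nc(Nc2ccc(C#N)cc2)n1` stands at 29300 nM and compound 2 `Cc1cc(-c2cccc(F)c2)cc(C)c1Oc1cc(N)nc(Nc2ccc(C#N)cc2)n1` at 24700 nM while compound 3 `Cc1cccc(-c2cc(C)c(Oc3cc(N)nc(Nc4ccc(C#N)cc4)n3)c(C)c2)c1` stands at 27600 nM with all three within the usual scatter of one another, so compound 3 holds no real rank among them. Compound 4 `COc1ccccc1-c1cc(C)c(Oc2cc(N)nc(Nc3ccc(C#N)cc3)n2)c(C)c1` carries 2-methoxyphenyl in place of 3-methylphenyl on an aromatic carbon. Three measured changes of this group bear on it: a 1.2-fold lower number from compound 1 to compound 2 (0.07 log units; within the scatter) and a 1.1-fold lower number from compound 1 to compound 3 (0.03 log units; within the scatter) and a 1.1-fold higher number from compound 2 to compound 3 (0.05 log units; within the scatter) all stay within the scatter. Among the compounds with values here, no measured compound carries a methoxy group, so this comparison is only indirect. In this assay the estimated 1.0-fold lower number from compound 3 to compound 4 (0.01 log units; within the scatter) is expected to stay within the scatter as well. The expected value for compound 4 is 27000 nM with an estimated range (15000 nM to 45000 nM).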

Compound 4, half-maximal cytotoxic concentration: 21800 nM
Beside the measured number, compound 4's estimate is 1.2-fold (0.09 log units) above it; the measured number falls inside the stated range.
By their numbers in this assay, from the lowest: compounds 4, 2, 3 and 1 (each within the scatter of the next).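

In this assay there is a 1.3-fold lower number from compound 3 to compound 4 (0.10 log units; within the scatter) and a 1.1-fold lower number from compound 2 to compound 4 (0.05 log units; within the scatter) and also a 1.3-fold lower number from compound 1 to compound 4 (0.13 log units; within the scatter) across the methoxy swaps. This position therefore accepts a ring substituent containing oxygen, a hydrogen-bond acceptor, with every step still inside the scatter. Nothing measured here explains why the numbers stay so close.

As far as these compounds go, whether a phenyl ring carrying an amine or a carboxylic acid would also stay within the scatter remains open. The same is true of replacing the ring's methoxy group with a longer chain such as butoxy.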